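The source may hold more compounds than are shown below. What is called first, only, known or untested is meant among the compounds shown, and "the series" means these compounds.

Of the compounds shown here, two from one series have been measured in a functional assay on RAW264.7 cells (Mus musculus) for inhibition, read by immunoassay, with a stated time of 12 h, tested at 30 uM; on this read-out higher numbers stand for more inhibition at the one concentration tested (going by the name of the read-out) and lower numbers for less inhibition. Compound 1, `O=C1CC(c2ccccc2OCc2ccc(F)cc2)Oc2ccccc21`, gives 45.2%. Compound 2, `CC(C)COc1ccccc1C1CC(=O)c2ccccc2O1`, gives 30.4%. For the measured compounds named here, the one measured step, a number 14.8 percentage points lower from compound 1 to compound 2 (beyond the scatter), is the only comparison available, and it leaves compound 2 as the lower of the two numbers, with compound 1 standing above it.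

Compound 3, `CC(C)=CCOc1ccccc1C1CC(=O)c2ccccc2O1`, is the next member: it differs from compound 2 by 2-methylprop-1-en-1-yl in place of isopropyl on a saturated chain carbon bound to an oxygen on an aromatic ring. The measured step touched the same saturated chain carbon bound to an oxygen on an aromatic ring, but it exchanged a ring for a small chain, whereas here a three-carbon chain gives way to a four-carbon chain carrying one double bond outside aromatic rings. That step was modest and offers no direct reading of how this smaller change will fall out in this assay.

On that basis the account expects only a small rise for compound 3, a number 4.6 percentage points higher from compound 2 to compound 3 (within the scatter), lying within or just at the edge of the scatter. Compound 3 is therefore estimated at 35%, with a range from 20% to 50%.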

Compound 3, a percentage reported as inhibition, at one concentration (the size of the read-out at that concentration, not a potency): 41.8%
Compound 3: the middle estimate sits 6.8 percentage points below what was measured; the range from low to high includes it.
By their numbers in this assay, from the lowest: compound 2; then compounds 3 and 1 (each within the scatter of the next).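

In this assay, 2-methylprop-1-en-1-yl in place of isopropyl on a saturated chain carbon bound to an oxygen on an aromatic ring gives a number 11.4 percentage points higher from compound 2 to compound 3 (beyond the scatter), which shows that at this place a change from one open chain to another, with no ring entering or leaving, can move the read-out beyond the scatter. The 4-fluorophenyl group is also not needed to reach this level of inhibition: with 2-methylprop-1-en-1-yl in its place, the result is a number 3.4 percentage points lower from compound 1 to compound 3 (within the scatter), so the ring and this unsaturated chain cannot be told apart here, and the earlier drop cannot be read as a simple loss of the ring. Nothing available explains why these groups give these numbers.

The entering group differs from isopropyl both by its added carbon and by its double bond, and the compounds shown do not separate the two, which a saturated isopentyl chain at this place could begin to do. Also open, from the compounds shown here alone, is how the read-out would respond to a chain ending in an amine or a carboxylic acid.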